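Cytotoxicity in the acyl-thiourea series: compound 2 to compound 3

The source may hold more compounds than are shown below. What is called first, only, known or untested is meant among the compounds shown, and "the series" means these compounds.

Measured so far:
- compound 1, `O=C(NC(=S)N1CCc2cccc(OCc3ccccc3)c21)c1ccccc1`: > 50000 nM
- compound 2, `Cc1ccc(C(=O)NC(=S)N2CCc3c(OCCCCCOc4ccc(Cl)cc4)cccc32)cc1`: > 50000 nM

The two measured compounds have been run in an ADME assay on Huh-7 cells (Homo sapiens) for cytotoxicity; a lower number here means that less compound is tolerated, a higher number that more compound is tolerated. For compound 1 the result is a limit rather than a number, > 50000 nM. For compound 2 the result is likewise a limit, > 50000 nM. Going by the values given here, compound 2 therefore stands at the upper edge of what this assay reports, and the one further value shown sits at the same edge, as the limit of > 50000 nM in this assay, at which 2 of the 2 values shown sit, states. Among the compounds with values here, nothing among the measured pairs differs in a single place, so no measured step is available for comparison.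

Compound 3, `O=C(NC(=S)N1CCc2c(OCCCCCOc3ccc(Cl)cc3)cccc21)c1ccc2ccccc2c1`, has not yet been measured in this assay. It differs from compound 2 in one place: naphthalen-2-yl in place of 4-methylphenyl on a carbonyl carbon. With both measured values resting at the limit, no direction can be read from the data. The step from compound 2 to compound 3 is expected to stay within the scatter, a number no higher from compound 2 to compound 3 (the limit leaves the size open). For compound 3 the expected result in this assay is 50000 nM, with a range from 20000 nM to 100000 nM, most likely reported again as a limit.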

Compound 3, half-maximal cytotoxic concentration: > 50000 nM
Compound 3: only a limit was reported; the forecaster's own chance of this, stated with the estimate: 75%; the middle value lies on the limit itself.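

In this assay compound 3 gives > 50000 nM, a limit and not a number. Compound 2 and compound 3 both rest at a limit, so no step can be read between them: the limit of > 50000 nM in this assay, at which 3 of the 3 values shown sit.

The compounds shown leave open at what concentration any of them becomes cytotoxic, and whether naphthalen-2-yl in place of 4-methylphenyl on a carbonyl carbon changes that concentration.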